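Bromo for hydrogen on the isatin-type core of compound 3

The source may report more compounds than this note shows. Statements on the series, on what has been measured and on what is new or still open speak of the compounds shown alone.

The measured compounds in a functional assay on MDA-MB-468 cells (Homo sapiens) for cytotoxicity, read by sulforhodamine B assay, with a stated time of 48 h (on this read-out lower numbers stand for stronger inhibition of growth and higher numbers for weaker inhibition of growth), are:
- compound 1 `Cc1ccc2nc(/N=C3\C(=O)N(CN4CCCCC4)c4ccccc43)sc2c1` gives 65600 nM
- compound 2 `O=C1C(=O)N(CN(c2ccccc2)c2ccccc2)c2cccc(Cl)c21` gives 14400 nM
- compound 3 `O=C1C(=O)N(CN(c2ccccc2)c2ccccc2)c2ccccc21` gives 21500 nM

Compound 3 stands second highest of the three numbers in this assay. Its nearest neighbour is compound 2, and the gap between them is within the scatter; the furthest is compound 1, and that gap lies beyond the scatter. The step from compound 2 to compound 3 is a 1.5-fold higher number from compound 2 to compound 3 (0.17 log units; within the scatter), a change of hydrogen in place of chloro on an aromatic carbon that did not move the number beyond the scatter.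

Compound 4 `O=C1C(=O)N(CN(c2ccccc2)c2ccccc2)c2cccc(Br)c21` differs from compound 3 by bromo in place of hydrogen on an aromatic carbon. Within the data shown here, the only step that bears on this change is the one between compound 2 and compound 3, where a halogen at the same position gave a 1.5-fold higher number from compound 2 to compound 3 (0.17 log units; within the scatter). A bromo at that position is therefore expected to behave much like the chloro of compound 2, giving at most a small movement that stays within the scatter. The estimate for compound 4 in this assay is 15000 nM, with a range from 5000 nM to 45000 nM. This expected step from compound 3 to compound 4 is a 1.4-fold lower number from compound 3 to compound 4 (0.16 log units; within the scatter).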

Compound 4, concentration for 50% growth inhibition: 63300 nM
Beside the measured number, compound 4's estimate is 4.2-fold (0.63 log units) below it, outside the stated range (above it).
By their numbers in this assay, from the lowest: compounds 2 and 3 (each within the scatter of the next); then compounds 4 and 1 (each within the scatter of the next).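

In this assay this aromatic carbon proves sensitive to what it carries: bromo in place of hydrogen gives a 2.9-fold higher number from compound 3 to compound 4 (0.47 log units; beyond the scatter) and so moves the number beyond the scatter, which the earlier exchange of chloro and hydrogen did not do. The two halogens also separate, with bromo in place of chloro giving a 4.4-fold higher number from compound 2 to compound 4 (0.64 log units; beyond the scatter) so that, in this series, bromo cannot be read as a stand-in for chloro. Nothing measured here accounts for this difference between the two halogens.

With only hydrogen, chloro and bromo shown at this carbon, it remains open how a methyl group, a methoxy group, an amine or a carboxylic acid would fare there. It also remains open whether the bromo step would hold if the diphenylamino group of these compounds were replaced by a piperidine.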